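From bromo to fluoro in a small halogen series

The source may hold more compounds than are shown below. What is called first, only, known or untested is meant among the compounds shown, and "the series" means these compounds.

- Compound 1 `O=C1NC(=S)/C(=C/c2ccc(Cl)cc2)S1` gives 16.1%
- Compound 2 `O=C1NC(=S)/C(=C/c2ccccc2Br)S1` gives 16.2%
- Compound 3 `O=C1NC(=S)/C(=C/c2ccc(Br)cc2)S1` gives 15.4%

In a functional assay on HEp-2 cells (Homo sapiens) for cytotoxicity, read by MTT assay, with a stated time of 72 h, tested at 5 ug/mL (a lower number here means less inhibition of growth, a higher number more inhibition of growth at the concentration tested), compound 3 gives 15.4%, within the scatter of both compound 1 and compound 2. Compound 4 `O=C1NC(=S)/C(=C/c2ccc(F)cc2)S1` differs from compound 3 as follows: fluoro in place of bromo on an aromatic carbon. This places fluoro in place of bromo on an aromatic carbon. Going by the values given here, only one measured step bears on this change, the exchange of one halogen for another at an aromatic carbon: a number 0.7 percentage points lower from compound 1 to compound 3 (within the scatter). That step stays within the scatter, and fluoro itself has not yet been measured, so no step beyond the scatter is expected. The expected step is a number 0.6 percentage points higher from compound 3 to compound 4 (within the scatter). The estimated value for compound 4 is 16%, with an expected range of 7% to 27%.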

Compound 4, percent growth inhibition at one concentration: 20.6%
The estimate for compound 4 lay 4.6 percentage points below the measured number, within the range that was stated.
By their numbers in this assay, from the lowest: compounds 3, 1, 2 and 4 (each within the scatter of the next).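

At the aromatic carbon para to a group of 8 heavy atoms, fluoro in place of bromo gives a number 5.2 percentage points higher from compound 3 to compound 4 (within the scatter) and fluoro in place of chloro gives a number 4.5 percentage points higher from compound 1 to compound 4 (within the scatter) in this assay so fluoro joins chloro and bromo within the scatter of one another. Exchanging one of these halogens for another at this place has therefore not moved the number beyond the scatter. No measurement offered here explains the small differences among these compounds.

Still open, going by these compounds, is whether a group other than a halogen at this place, such as an amine, a carboxylic acid or a methoxy group, would move the number beyond the scatter.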